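Trading phenethylcarbonyl for 2,4-dinitrophenyl on the amine nitrogen

The source may report more compounds than this note shows. Statements on the series, on what has been measured and on what is new or still open speak of the compounds shown alone.

In a toxicity assay on KB cells (Homo sapiens) for cytotoxicity, read by fluorescence, with a stated time of 3 days (a lower number here means that less compound is needed, a higher number that more compound is needed for the effect), compound 1 `CCCCOC(=O)CNC(=O)[C@H](CSc1ccc([N+](=O)[O-])cc1[N+](=O)[O-])NC(=O)CC[C@H](NC(=O)/C=C/c1ccccc1)C(=O)OCCCC` gives 34.4 uM. Compound 2 `CCCCOC(=O)CNC(=O)[C@H](CSc1ccc([N+](=O)[O-])cc1[N+](=O)[O-])NC(=O)CC[C@H](NC(=O)CCc1ccccc1)C(=O)OCCCC` reads > 300 uM, which is a limit of the assay and not a number. Compound 2 therefore offers no measured number to start from. Compound 3 `CCCCOC(=O)CNC(=O)[C@H](CSc1ccc([N+](=O)[O-])cc1[N+](=O)[O-])NC(=O)CC[C@H](Nc1ccc([N+](=O)[O-])cc1[N+](=O)[O-])C(=O)OCCCC` differs from compound 2 by having 2,4-dinitrophenyl in place of phenethylcarbonyl on an amine nitrogen. Going by the values given here, one measured step bears on this change, namely an at least 8.7-fold higher number from compound 1 to compound 2 (0.94 log units; beyond the scatter), with phenethyl in place of 2-phenylethenyl on a carbonyl carbon. That step lies beyond the scatter and alters the same group that compound 3 gives up, so a change in this group can clearly shift the result. It is thin ground, however, since 2,4-dinitrophenyl has not been measured at this place. Among the compounds with values here, with compound 1 at 34.4 uM as the only number available, a step toward a lower number is expected, of at least modest size. The estimated step is an at least 5.0-fold lower number from compound 2 to compound 3 (0.69 log units; beyond the scatter). For compound 3 the expected value is 60 uM, with an estimated range of 12 uM to 300 uM.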

Compound 3, concentration for half-maximal effect: > 300 uM
Compound 3 ended at the assay's limit (the forecaster's own chance of this, stated with the estimate: 25%); middle value at least 5.0-fold (0.69 log units) away from the limit.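

Set against compound 1 on this amine nitrogen, 2,4-dinitrophenyl in place of (2-phenylethenyl)carbonyl gives, in this assay, an at least 8.7-fold higher number from compound 1 to compound 3 (0.94 log units; beyond the scatter). Before this, only phenethylcarbonyl had been set against (2-phenylethenyl)carbonyl, so a single replacement carried the whole picture. Now two different groups at this place have left the measurable range, and (2-phenylethenyl)carbonyl is the only one of the three that gives a number and not a limit. Compound 3 reads a limit and not a number, and the step from compound 2 has no readable size, so phenethylcarbonyl and 2,4-dinitrophenyl cannot be put in order: the limit of > 300 uM in this assay, at which 2 of the 3 values shown sit.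

On these data alone, what remains open is how far past the limit compound 2 and compound 3 lie, and so whether the two groups differ at all in this assay. Also open, as far as these compounds go, is whether a free amine, a simple acetyl amide or a cinnamoyl-type amide with a longer chain on this nitrogen would give a number, and so whether the low value of compound 1 depends on the (2-phenylethenyl)carbonyl group itself.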